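The source may hold more compounds than are shown below. What is called first, only, known or untested is meant among the compounds shown, and "the series" means these compounds.

Compound 2 `CC(C)C[C@H](N)c1cc(C(F)(F)F)ccc1N1CCN(C(=O)CCc2cccc(C(F)(F)F)c2)CC1` gives the higher of the two numbers measured in an assay on HEK293 cells for displacement of a labelled ligand from Melanocortin receptor 4 (Homo sapiens) (on this read-out higher numbers stand for weaker inhibition and lower numbers for stronger inhibition), where compound 2 gives 2200 nM. Compound 1 `CCC(C)[C@H](N)c1cc(C(F)(F)F)ccc1N1CCN(C(=O)CCc2ccc(OC)cc2Cl)CC1` differs from compound 2 in more than one place, and in this assay compound 1 gives 57 nM, a gap that lies well beyond the usual scatter. Compound 3 `COc1cc(OC)c(OC)cc1CCC(=O)N1CCN(c2ccc(C(F)(F)F)cc2[C@@H](N)CC(C)C)CC1` has not been measured; it differs from compound 2 in one place: 2,4,5-trimethoxyphenyl in place of 3-(trifluoromethyl)phenyl on a saturated chain carbon, two bonds along the chain from a carbonyl carbon. Within the data shown here, no single-change step between measured compounds is at hand to calibrate this exchange. The aryl group of compound 2 also differs from that of compound 1, and since compound 1 gives 57 nM, a change in this part of the molecule can shift the number strongly. Compound 3 is expected to show a step of a 4.4-fold lower number from compound 2 to compound 3 (0.64 log units; beyond the scatter) toward stronger inhibition. Compound 3 is therefore estimated at 500 nM, within a range from 100 nM to 3000 nM.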

Compound 3, inhibition constant: 6100 nM
Compound 3: middle estimate off by 12-fold (1.09 log units), on the low side; the measured number lies above the stated range.
By their numbers in this assay, from the lowest: compound 1; then compound 2; then compound 3.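

In this assay there is a 2.8-fold higher number from compound 2 to compound 3 (0.44 log units; beyond the scatter) when 2,4,5-trimethoxyphenyl enters in place of 3-(trifluoromethyl)phenyl on a saturated chain carbon, two bonds along the chain from a carbonyl carbon. Among these compounds, this is the first single-change reading at this position, and it shows that the exchange moves toward weaker inhibition, even though the entering group carries hydrogen-bond acceptors and the leaving group carries none. Nothing measured here accounts for this step.

The compounds shown leave open whether the step comes from losing the trifluoromethyl group or from adding the methoxy groups, and how an aryl group bearing a single methoxy group or a nitrile would read. They also leave open whether the same exchange would give a similar step on the core of compound 1.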